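Solubility notes on one ester series

The source may hold more compounds than are shown below. What is called first, only, known or untested is meant among the compounds shown, and "the series" means these compounds.

Measured so far in a physicochemical assay for solubility, in phosphate buffer, at pH 7.4; on this read-out lower numbers stand for lower solubility and higher numbers for higher solubility:
compound 1 `CCOC(=O)c1c(-c2cccs2)[nH]c2cc(OC)ccc2c1=O`, > 100000 nM — a limit of the assay, not a number
compound 2 `CCOC(=O)c1c(-c2cccc([N+](=O)[O-])c2)[nH]c2cccc(OC)c2c1=O`, 49000 nM
compound 3 `CCOC(=O)c1c(-c2ccc(C(C)(C)C)cc2)[nH]c2cc(OC)ccc2c1=O`, 2000 nM

Compound 1 sits only at the limit of > 100000 nM in this assay, at which 1 of the 3 values shown sits, so this assay gives it a range and no point value. Compound 2 gives 49000 nM. Compound 3, with its tert-butylphenyl, gives 2000 nM, the lowest number among the three.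

Compound 4 `CCOC(=O)c1c(-c2cccc(C)c2)[nH]c2cc(OC)ccc2c1=O` is not yet measured. (3-methylphenyl in place of thiophen-2-yl on an aromatic carbon). Among the measured compounds shown here, no pair of measured compounds differs by this change alone, so its size is not known from the data. The step from compound 1 to compound 4 is expected to be an at least 4.0-fold lower number from compound 1 to compound 4 (0.60 log units; beyond the scatter), downward and beyond the scatter, with compound 3 at 2000 nM as the nearest guide. Compound 4 is thus estimated at 25000 nM, with a range of 6000 nM to 100000 nM.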

Compound 4, solubility: 48000 nM
Estimate against measurement, compound 4: 1.9-fold (0.28 log units) below; the measured number falls inside the stated range.
By their numbers in this assay, from the lowest: compound 3; then compounds 4 and 2 (each within the scatter of the next). At a limit, above all of these: compound 1.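

In this assay, this aromatic carbon next to the ring nitrogen now has its first single-place step, with 3-methylphenyl in place of thiophen-2-yl: an at least 2.0-fold lower number from compound 1 to compound 4 (0.31 log units; beyond the scatter). The change therefore moves the read-out beyond the scatter. Compound 1 stands at a limit of the assay, so the step sets a minimum and not a size: the limit of > 100000 nM in this assay, at which 1 of the 4 values shown sits.

Going by these compounds, whether the step follows from the ring exchange or from the methyl group stays open, and plain phenyl at this carbon would separate the two. On these data alone, the effect of an amine or a carboxylic acid on this aryl ring is also open.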